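The source may report more compounds than this note shows. Statements on the series, on what has been measured and on what is new or still open speak of the compounds shown alone.

Compounds measured so far in an ADME assay on HepG2 cells (Homo sapiens) for cytotoxicity, read by luminescence, CellTiter-Glo and ATP content, with a stated time of 72 h; a lower number here means that less compound is needed, a higher number that more compound is needed for the effect:
compound 1, `COc1cccc(CNCCCNc2ccnc3cc(CCC(C)C)ccc23)c1O`, gives 5390 nM.
compound 2, `COc1cccc(CNCCCNc2ccnc3cc(Oc4cccc(N(C)C)c4)ccc23)c1O`, gives 7300 nM.
compound 3, `COc1cccc(CNCCCNc2ccnc3cc(Oc4ccc(C(C)(C)C)cc4)ccc23)c1O`, gives 1500 nM.

Compound 3 stands lowest of the three in this assay. The step of a 3.6-fold lower number from compound 1 to compound 3 (0.56 log units; beyond the scatter) and the step of a 4.9-fold lower number from compound 2 to compound 3 (0.69 log units; beyond the scatter) both lie beyond the scatter, whereas a 1.4-fold higher number from compound 1 to compound 2 (0.13 log units; within the scatter) stays within it. Compound 4, `COc1cccc(CNCCCNc2ccnc3cc(-c4ccc(C(F)(F)F)cc4)ccc23)c1O`, has not yet been measured in this assay. It differs from compound 3 in one place: 4-(trifluoromethyl)phenyl in place of 4-(tert-butyl)phenoxy on an aromatic carbon. The two measured steps that reach compound 3 both concern this same place on the shared core, and both are modest in size. Within the data shown here, no measured compound carries a phenyl joined directly to that aromatic carbon without an oxygen, and the direction of the step is therefore open. The modest size of the steps into compound 3 suggests that a change at this place shifts the number by a modest amount at most. Compound 4 is expected to land near compound 3, with an expected step of a 1.7-fold higher number from compound 3 to compound 4 (0.22 log units; within the scatter) that may not exceed the scatter. The estimate for compound 4 is 2500 nM, with a range from 800 nM to 8000 nM.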

Compound 4, half-maximal effective concentration: 2210 nM
Compound 4: middle estimate off by 1.1-fold (0.05 log units), on the high side, within the range that was stated.
By their numbers in this assay, from the lowest: compounds 3 and 4 (each within the scatter of the next); then compounds 1 and 2 (each within the scatter of the next).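

In this assay, the step of a 1.5-fold higher number from compound 3 to compound 4 (0.17 log units; within the scatter) shows that 4-(trifluoromethyl)phenyl, with no oxygen between its ring and the shared core, can take the place of 4-(tert-butyl)phenoxy without a change beyond the scatter. Both a 3.3-fold lower number from compound 2 to compound 4 (0.52 log units; beyond the scatter) and a 2.4-fold lower number from compound 1 to compound 4 (0.39 log units; beyond the scatter) lie beyond the scatter, so the lower number seen earlier only with 4-(tert-butyl)phenoxy does not depend on an oxygen at this aromatic carbon. A six-membered aromatic ring here does not set the number alone: compound 2 carries one too, yet it stays within the scatter of compound 1, which has isopentyl. Nothing at hand accounts for these differences.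

The compounds shown leave open what the oxygen contributes on its own: no pair carries the same substituted ring with and without it, so the oxygen and the exchange of tert-butyl for trifluoromethyl cannot be separated. They also leave open how a carboxylic acid or a primary amine on the phenyl ring, or a longer chain in place of isopentyl, would move the number.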